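Acetyl to dimethylamino swap: compound 1 to compound 3

The source may report more compounds than this note shows. Statements on the series, on what has been measured and on what is new or still open speak of the compounds shown alone.

Two compounds of the series have numbers in a functional assay on A549 cells (Homo sapiens) for cytotoxicity, read by sulforhodamine B assay, with a stated time of 48 h, tested at 1 uM; a lower number here means a stronger effect, a higher number a weaker effect of the compound at the concentration tested. Compound 1 `COc1cc(C)cc(-c2c(-c3ccnc(-c4ccc(C(C)=O)cc4)c3)cnn2CC#N)c1` gives 25% in this assay. Compound 2 `Cc1cc(O)cc(-c2nn(CC#N)cc2-c2ccnc(-c3ccc(Oc4ccccc4)cc3)c2)c1` gives -37% in this assay. On these two numbers compound 1 stands highest, with compound 2 the nearest, a number lower by a gap beyond the scatter; the two differ in more than one place, so their values say nothing about any single change. Compound 3 `COc1cc(C)cc(-c2c(-c3ccnc(-c4ccc(N(C)C)cc4)c3)cnn2CC#N)c1` is not yet measured in this assay. It departs from compound 1 by one change: dimethylamino in place of acetyl on an aromatic carbon. Within the data shown here, no measured pair shows this change, and nothing ties a change at that site to a shift in this assay. The step is therefore expected to be small, no more than the scatter in either direction, estimated as a number 5 percentage points lower from compound 1 to compound 3 (within the scatter). Compound 3 is expected to give 20% in this assay, within -20% to 55%.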

Compound 3, a percentage reported as activity, at one concentration (the size of the read-out at that concentration, not a potency): 5%
Compound 3: middle estimate off by 15 percentage points, on the high side; the range from low to high includes it.
By their numbers in this assay, from the lowest: compound 2; then compound 3; then compound 1.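

Among these compounds, this is the first single-change step. In this assay, placing dimethylamino in place of acetyl on the aromatic carbon para to a large group gives a number 20 percentage points lower from compound 1 to compound 3 (beyond the scatter), so this position responds to the change, and the direction is towards a stronger effect at the concentration tested. The two groups match in heavy-atom and hydrogen-bond acceptor counts, so those counts alone do not fix the read-out here, and nothing at hand accounts for the step.

A single step cannot separate the loss of acetyl from the arrival of dimethylamino. Going by these compounds, a carboxylic acid or a morpholine on the same carbon, with the rest of compound 1 unchanged, would bear on that question, and whether the step carries over to other substituents on the shared core remains open.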